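The source may hold more compounds than are shown below. What is called first, only, known or untested is meant among the compounds shown, and "the series" means these compounds.

Measured so far:
compound 1, `NCCCNc1c(C(=O)NCc2ccc(F)cc2)nc(Br)c2cccnc12`, in a functional assay on MCF7 cells (Homo sapiens) for cytotoxicity, read by MTT assay, with a stated time of 72 h; a lower number here means a stronger inhibitor, a higher number a weaker inhibitor: 6000 nM
compound 2, `COC(=O)c1nc(Br)c2cccnc2c1N[C@H]1CC[C@H](N)CC1`: a limit, > 20000 nM

Of the compounds shown here, two have been tested in this assay. Among the compounds with values here, compound 1 gives 6000 nM, the only resolved number among the two values shown. For compound 2 the result is a limit of the assay, > 20000 nM. Compound 1 thus stands alone as the single measured figure, the other value sitting at the limit of > 20000 nM in this assay, at which 1 of the 2 values shown sits. Within the data shown here, no two measured compounds differ in one place, so no measured step is available for comparison.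

The unmeasured compound 3, `CNCCCNc1c(C(=O)NCc2ccc(F)cc2)nc(Br)c2cccnc12`, differs from compound 1 by methyl in place of hydrogen on an amine nitrogen, the amino end of the side chain becoming methylamino. Among the measured compounds shown here, with no measured step of this kind to draw on, the account expects a change from compound 1 to compound 3 of a 1.2-fold lower number from compound 1 to compound 3 (0.08 log units; within the scatter) in this assay, a step not beyond the usual scatter in either direction. Compound 3 is accordingly estimated at 5000 nM, within a range from 2000 nM to 15000 nM.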

Compound 3, half-maximal inhibitory concentration: > 10000 nM
Compound 3: only a limit was reported; the forecaster's own chance of this, stated with the estimate: 15%; middle value at least 2.0-fold (0.30 log units) away from the limit.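

In this assay, methyl in place of hydrogen on an amine nitrogen, the amino end of the side chain becoming methylamino, now has its first measured step, which the two earlier compounds could not give: an at least 1.6-fold higher number from compound 1 to compound 3 (0.22 log units; that floor lies within the scatter). For compound 3 the result is a limit of the assay and not a number: the limit of > 10000 nM in this assay, at which 1 of the 3 values shown sits. The step therefore gives a floor and no size, and although that floor lies within the scatter, the change shows no sign of a lower number at this position, leaving compound 1 as the only compound shown with a resolved value.

The compounds shown leave open how large the step really is, since the true figure for compound 3 could lie close to its limit or far beyond it. They also leave open whether this nitrogen responds in the same way to other changes, such as a dimethylamino end, an ethylamino end or a longer chain carrying the primary amine, and whether the same methyl step would read alike on other members of the series.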